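This account rests on a few compounds, and the source may have more. Where it says the series, first, only, none or still open, it means among the compounds named here.

In an assay on isolated protein for inhibition of histone deacetylase 4 (Homo sapiens), with a stated time of 1 h (on this read-out lower numbers stand for stronger inhibition and higher numbers for weaker inhibition), compound 1 `COc1cccc(NC(=O)COc2ccc3cc(/C=C4/SC(=O)NC4=O)ccc3c2)c1` stands highest of the two numbers recorded, at 1600 nM. Its nearest neighbour is compound 2 `O=C(COc1ccc2cc(/C=C3/SC(=O)NC3=O)ccc2c1)Nc1cccc(F)n1`, which in this assay gives 840 nM; the step of a 1.9-fold lower number from compound 1 to compound 2 (0.28 log units; within the scatter) lies within the scatter, so the two values cannot be told apart.

Compound 3 `O=C(COc1ccc2cc(/C=C3/SC(=O)NC3=O)ccc2c1)Nc1cccc(C(F)(F)F)c1` is reached from compound 1 by one change: trifluoromethyl in place of methoxy on an aromatic carbon. Going by the values given here, the only measured step available, a 1.9-fold lower number from compound 1 to compound 2 (0.28 log units; within the scatter), replaces the whole ring on the amide-type nitrogen rather than a single group on it, and it stayed within the scatter. Among the compounds with values here, no measured pair tests a substituent swap on that ring itself. The evidence therefore points to no step beyond the scatter, in either direction, and the uncertainty is wide.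

On that basis compound 3 is expected to give 1400 nM in this assay, within a range from 500 nM to 4000 nM. The expected step of a 1.1-fold lower number from compound 1 to compound 3 (0.06 log units; within the scatter) is estimated to remain within the scatter.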

Compound 3, half-maximal inhibitory concentration: 2500 nM
For compound 3 the middle estimate is 1.8-fold (0.25 log units) below the measured one; the range from low to high includes it.
By their numbers in this assay, from the lowest: compounds 2, 1 and 3 (each within the scatter of the next, the first and the last beyond it).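

In this assay, a substituent swap on the ring itself can now be read: a 1.6-fold higher number from compound 1 to compound 3 (0.19 log units; within the scatter), so trifluoromethyl and methoxy on this aromatic carbon, meta to a large group, cannot be told apart, even though the two groups differ in heavy atoms and hydrogen-bond acceptors. The three compounds also yield their first separation beyond the scatter, though only a modest one: a 3.0-fold higher number from compound 2 to compound 3 (0.47 log units; beyond the scatter), between the 6-fluoropyridin-2-yl and 3-(trifluoromethyl)phenyl groups on the amide-type nitrogen, while compound 1 lies within the scatter of both compound 2 and compound 3. No evidence is available that bears on the reason for either step.

The compounds shown leave open whether the gap between compound 2 and compound 3 follows the ring nitrogen, the fluorine or the trifluoromethyl group, since that step exchanges the whole ring at once. They also leave open whether a group of another kind at the position of the methoxy, such as an amine or a carboxylic acid, would move the number beyond the scatter.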